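Phenoxy for Benzylamino on a Diamino Core

The source may hold more compounds than are shown below. What is called first, only, known or untested is meant among the compounds shown, and "the series" means these compounds.

Measured so far:
- compound 1 `Nc1cc(N)c2nc(-c3ccccc3)c(NCc3ccc(F)cc3)nc2c1`: 19500 nM
- compound 2 `COc1ccc(CNc2nc3cc(N)cc(N)c3nc2-c2ccccc2)cc1`: 64600 nM

Among the measured compounds shown here, in a functional assay on MDA-MB-231 cells (Homo sapiens) for inhibition, read by sulforhodamine B assay, with a stated time of 48 h (a higher number here means that more compound is tolerated, a lower number that less compound is tolerated), compound 1 gives the lowest of the two numbers; the only neighbour, compound 2, sits at a 3.3-fold higher number from compound 1 to compound 2 (0.52 log units; beyond the scatter). Compound 3 `Nc1cc(N)c2nc(-c3ccccc3)c(Oc3ccc(F)cc3)nc2c1` keeps the shared core and differs from compound 1 by 4-fluorophenoxy in place of (4-fluorobenzyl)amino on an aromatic carbon. For the measured compounds named here, no measured step changes this linker; the one known step alters only a substituent on the outer ring, so it offers little guidance. The expected step from compound 1 to compound 3 is a 1.5-fold higher number from compound 1 to compound 3 (0.19 log units; within the scatter), with a wide range. Compound 3 is estimated at 30000 nM, between 8000 nM and 120000 nM.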

Compound 3, concentration lethal to 50% of the cells: < 100000 nM
Compound 3 was reported as a limit; the forecaster's own chance of this, stated with the estimate: 10%; the middle value does not contradict the limit.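

Compound 3 is reported only as the limit < 100000 nM and not as a number, so its step from compound 1 cannot be read. The compounds shown leave open whether 4-fluorophenoxy in place of (4-fluorobenzyl)amino raises or lowers the number, and by how much.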